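A few compounds are considered here, and "the series" means these few. Any claim that something is new, unique, unknown or untested is made for them only; others in the source may bear on it.

Measured in a functional assay on A549 cells (Homo sapiens) for inhibition, read by CCK-8 assay, with a stated time of 72 h, tested at 2 uM; a lower number here means less inhibition of growth, a higher number more inhibition of growth at the concentration tested:
- compound 1 `Nc1ccccc1NC(=O)/C=C/c1ccc(CSc2ccc(Cl)cc2)cc1`: 55.3%
- compound 2 `COc1ccc(SCc2ccc(C(=O)Nc3ccccc3N)cc2)cc1`: 45.7%
- compound 3 `Nc1ccccc1NC(=O)c1ccc(CSc2cccc(F)c2)cc1`: 46.9%

In this assay, compound 1 at 55.3% lies within the scatter of both other compounds, so the three numbers cannot be ranked. Compound 4 `Cc1ccc(SCc2ccc(/C=C/C(=O)Nc3ccccc3N)cc2)cc1` keeps the core of compound 1 and differs from it in one place: methyl in place of chloro on an aromatic carbon. This puts methyl in place of chloro on an aromatic carbon, para to a large group, turning the 4-chlorophenyl into a 4-methylphenyl.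

Among the compounds with values here, no measured pair shows this exact exchange. The nearest evidence is a change of the group on the sulfur, 3-fluorophenyl in place of 4-methoxyphenyl. That step, a number 1.2 percentage points higher from compound 2 to compound 3 (within the scatter), is small, although it was seen in compounds that differ from compound 1 elsewhere. On this limited evidence, no step beyond the scatter is expected in this assay, and no direction can be favoured with confidence. The expected step is a number 2.3 percentage points lower from compound 1 to compound 4 (within the scatter). For compound 4, the estimated value is 53%, with an expected range of 41% to 65%.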

Compound 4, percent growth inhibition at one concentration: 43.4%
For compound 4 the middle estimate is 9.6 percentage points above the measured one; measured number inside the range.
By their numbers in this assay, from the lowest: compounds 4, 2, 3 and 1 (each within the scatter of the next, the first and the last beyond it).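

In this assay, methyl in place of chloro on an aromatic carbon, para to a large group, gives a number 11.9 percentage points lower from compound 1 to compound 4 (beyond the scatter) and this is the only step shown that lies beyond the scatter. The earlier change of the group on the sulfur, a number 1.2 percentage points higher from compound 2 to compound 3 (within the scatter), had given no sign that the aryl group on the sulfur could matter, so this position is not indifferent to the group it carries, at least on the core of compound 1. Nothing available explains why the exchange of these two single-atom substituents has this effect.

On these data alone, whether the parent 4-chlorophenyl owes this edge to chloro specifically remains open, since bromo, trifluoromethyl or an amine at the same place could separate the two cases. As far as these compounds go, it also remains open whether the same exchange would give a similar step on the core of compound 2.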